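Series notes: a terminal hydroxy on the chain of compound 2

A few compounds are considered here, and "the series" means these few. Any claim that something is new, unique, unknown or untested is made for them only; others in the source may bear on it.

Of the compounds shown here, two have been measured in a functional assay on HCT-116 cells (Homo sapiens) for antiproliferative activity; on this read-out higher numbers stand for weaker inhibition and lower numbers for stronger inhibition. Compound 1 `CCO/N=C/c1c(N)ncnc1Oc1ccc2[nH]c(C)cc2c1F` gives 36 nM. Compound 2 `CCCO/N=C/c1c(N)ncnc1Oc1ccc2[nH]c(C)cc2c1F` gives 30 nM; the step of a 1.2-fold lower number from compound 1 to compound 2 (0.08 log units; within the scatter) is the only one available. Compound 2 thus holds the lower of the two measured numbers, but its gap to compound 1 lies within the scatter, so nothing separates the pair.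

Compound 3 `Cc1cc2c(F)c(Oc3ncnc(N)c3/C=N/OCCCO)ccc2[nH]1` is not yet measured. It differs from compound 2 by hydroxy in place of hydrogen on a saturated chain carbon, three bonds along the chain from an oxygen. Within the data shown here, the one measured step bears only loosely on this change: it concerns methyl in place of hydrogen on the chain, and it stayed within the scatter, as a 1.2-fold lower number from compound 1 to compound 2 (0.08 log units; within the scatter) shows. Among the measured compounds shown here, no measured step introduces a hydroxy anywhere, so the expectation rests on the small size of the one chain change seen so far. For compound 3 a step of a 1.1-fold higher number from compound 2 to compound 3 (0.03 log units; within the scatter) is expected, which is no change beyond the scatter. Compound 3 is therefore estimated at 32 nM, with a range from 12 nM to 85 nM.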

Compound 3, half-maximal inhibitory concentration: 452 nM
For compound 3 the middle estimate is 14-fold (1.15 log units) below the measured one; measured number outside the range, above it.
By their numbers in this assay, from the lowest: compounds 2 and 1 (each within the scatter of the next); then compound 3.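

In this assay, the hydroxy in place of hydrogen on a saturated chain carbon, three bonds along the chain from an oxygen, gives a 15-fold higher number from compound 2 to compound 3 (1.18 log units; beyond the scatter) and so marks this position as one where a single added heavy atom can matter greatly. The earlier chain change did not show this, since the methyl in place of hydrogen gave only a 1.2-fold lower number from compound 1 to compound 2 (0.08 log units; within the scatter) and left compound 1 and compound 2 within the scatter of each other. The weakening also holds against the shorter chain, as hydroxymethyl in place of hydrogen gives a 13-fold higher number from compound 1 to compound 3 (1.10 log units; beyond the scatter) and the propyl chain as such therefore does not account for the result; no measurement at hand bears on why the hydroxy has this effect.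

The compounds shown do not settle whether the loss belongs to the hydroxy itself or would also follow from another end group on the propyl chain, such as a methoxy, an amine or a carboxylic acid. On these data alone, it also remains open whether the hydroxy would give a step of similar size on a different chain, such as a 2-hydroxyethyl or a longer chain ending in hydroxy.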